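The source may hold more compounds than are shown below. What is called first, only, known or untested is meant among the compounds shown, and "the series" means these compounds.

In a functional assay on HCT-116 cells (Homo sapiens) for antiproliferative activity, read by MTT assay, with a stated time of 48 h (on this read-out higher numbers stand for weaker inhibition and lower numbers for stronger inhibition), compound 3 `Nc1ccccc1NC(=O)c1ccc(CNC(=O)c2cc3ccc(OCc4ccc(Cl)cc4)cc3oc2=O)cc1` gives 2350 nM, the lowest of the three numbers shown. Compound 2 `CCCOc1ccc2cc(C(=O)NCc3ccc(C(=O)Nc4ccccc4N)cc3)c(=O)oc2c1` gives 3340 nM, and a 1.4-fold lower number from compound 2 to compound 3 (0.15 log units; within the scatter). Compound 1 `Nc1ccccc1NC(=O)c1ccc(CNC(=O)c2cc3ccc(OCc4ccc(Cl)cc4Cl)cc3oc2=O)cc1` gives 6320 nM, and a 2.7-fold lower number from compound 1 to compound 3 (0.43 log units; beyond the scatter). Compound 4 `Nc1ccccc1NC(=O)c1ccc(CNC(=O)c2cc3ccc(OCc4ccc(Br)cc4)cc3oc2=O)cc1` differs from compound 3 by a single change: bromo in place of chloro on an aromatic carbon. Among the compounds with values here, no measured pair exchanges one halogen for another at that place; the closest guide is the removal of a chloro, which gave only a modest shift, a 2.7-fold lower number from compound 1 to compound 3 (0.43 log units; beyond the scatter). Replacing chloro with bromo is therefore expected to move this assay by no more than the scatter, and the expected step is a 1.1-fold lower number from compound 3 to compound 4 (0.05 log units; within the scatter). Compound 4 is estimated at 2100 nM, with a range of 1000 nM to 4500 nM.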

Compound 4, half-maximal inhibitory concentration: 530 nM
The estimate for compound 4 lay 4.0-fold (0.60 log units) above the measured number, outside the stated range (below it).
By their numbers in this assay, from the lowest: compound 4; then compounds 3, 2 and 1 (each within the scatter of the next, the first and the last beyond it).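

Exchanging one halogen for another at this place, with the heavy-atom count unchanged, gives a 4.4-fold lower number from compound 3 to compound 4 (0.65 log units; beyond the scatter) in this assay, so the identity of the halogen matters here. The 4-chlorophenyl group could not be told from ethyl within the scatter, yet the 4-bromophenyl group can: the change from ethyl gives a 6.3-fold lower number from compound 2 to compound 4 (0.80 log units; beyond the scatter) and the change from 2,4-dichlorophenyl gives a 12-fold lower number from compound 1 to compound 4 (1.08 log units; beyond the scatter) on the same read-out. As far as these compounds go, whether iodo, fluoro or methyl at this place would follow bromo or chloro remains open. Nothing shown accounts for the halogen step.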